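Benzyloxy for isopropyl in a urea series

The source may hold more compounds than are shown below. What is called first, only, known or untested is meant among the compounds shown, and "the series" means these compounds.

Measured so far:
compound 1 `CC(C)c1ccc(C2(CNC(=O)Nc3c(C(C)C)cccc3C(C)C)CCCC2)cc1` with 48 nM
compound 2 `CC(C)c1cccc(C(C)C)c1NC(=O)NCC1(c2cccc(OCc3ccccc3)c2)CCCC1` with 30 nM

Both compounds were tested in an assay on microsomes for inhibition of acyl-CoA:cholesterol acyltransferase (Oryctolagus cuniculus); on this read-out lower numbers stand for stronger inhibition and higher numbers for weaker inhibition. Within the data shown here, compound 1 gives 48 nM, the higher of the two numbers; its only neighbour, compound 2, gives 30 nM, a gap that lies within the scatter of repeated measurements, so no order between the two can be claimed. The next compound, compound 3 `CC(C)c1cccc(C(C)C)c1NC(=O)NCC1(c2ccc(OCc3ccccc3)cc2)CCCC1`, has not yet been measured in this assay. It differs from compound 1 by benzyloxy in place of isopropyl on an aromatic carbon. Among the measured compounds shown here, since no measured pair shows this exact change, its effect cannot be read from the existing data. Compound 2 carries the same entering group on another position of its ring, and its value of 30 nM suggests that a benzyloxy group is well tolerated in this series. For compound 3 a step of a 1.6-fold lower number from compound 1 to compound 3 (0.20 log units; within the scatter) is therefore expected, towards a lower number but likely still within the scatter. Compound 3 is estimated at 30 nM, with a plausible range from 10 nM to 100 nM.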

Compound 3, half-maximal inhibitory concentration: 34 nM
Compound 3: the middle estimate sits 1.1-fold (0.05 log units) below what was measured; low and high end bracket the measured number.
By their numbers in this assay, from the lowest: compounds 2, 3 and 1 (each within the scatter of the next).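

In this assay, the change from isopropyl to benzyloxy on this aromatic carbon, para to a large group, can now be read directly as a 1.4-fold lower number from compound 1 to compound 3 (0.15 log units; within the scatter) and thus gives no order between the two compounds. Compound 2 had shown benzyloxy only on another position of its ring, without a matching isopropyl partner; compound 3 now shows that the larger group with its added aromatic ring also fits this place, and compound 2 at 30 nM and compound 3 at 34 nM lie within the scatter of each other. No measurement shown here offers an explanation for this result.

The compounds shown leave open whether the oxygen or the terminal phenyl ring of benzyloxy matters at this carbon, which methoxy or phenyl there could help to separate. They also leave open how an amine or a carboxylic acid at this place would read in this assay.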